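The compounds below may be only part of what the source reports. "The series", "measured", "known", "first", "only" and "open" are said of these compounds alone.

Measured compounds:
- Compound 1, `COC(=O)/C=C/c1cccc(N(Cc2ccc(-c3ccc(F)c(Cl)c3)cc2)C(=O)C2CCCCC2)c1`: 66 nM
- Compound 2, `COC(=O)/C=C/c1cccc(N(Cc2ccc(-c3ccc(F)c(Cl)c3)cc2)C(=O)C(C)C)c1`: 129 nM

Both values come from an assay on isolated protein with Bile acid receptor (Homo sapiens) as the target; a higher number here means that more compound is needed for the effect, a lower number that less compound is needed. Compound 1 gives the lowest of the two numbers, but the gap to compound 2 is small: a 2.0-fold higher number from compound 1 to compound 2 (0.29 log units; within the scatter), so the two cannot be told apart with confidence.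

Compound 3, `COC(=O)/C=C/c1cccc(N(Cc2ccc(-c3ccc(OC(F)(F)F)cc3)cc2)C(=O)C2CCCCC2)c1`, has not yet been measured. It differs from compound 1 in a single respect: 4-(trifluoromethoxy)phenyl in place of 3-chloro-4-fluorophenyl on an aromatic carbon. Among the measured compounds shown here, the one measured step, from compound 1 to compound 2, concerns a different part of the molecule, the group on the carbonyl carbon, and so says nothing direct about the change at the aromatic carbon. For the measured compounds named here, with no comparable step available, there is no basis for expecting a shift beyond the scatter in either direction in this assay. The estimate for compound 3 is therefore kept close to compound 1: 90 nM, with a range from 30 nM to 300 nM, which means an expected step of a 1.4-fold higher number from compound 1 to compound 3 (0.13 log units; within the scatter).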

Compound 3, half-maximal effective concentration: 264 nM
Compound 3: middle estimate off by 2.9-fold (0.47 log units), on the low side; low and high end bracket the measured number.
By their numbers in this assay, from the lowest: compounds 1 and 2 (each within the scatter of the next); then compound 3.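

The aromatic group at this place matters more clearly in this assay than the earlier data could show: putting 4-(trifluoromethoxy)phenyl in place of 3-chloro-4-fluorophenyl gives a 4.0-fold higher number from compound 1 to compound 3 (0.60 log units; beyond the scatter). The earlier change on the carbonyl carbon, by contrast, gave a 2.0-fold higher number from compound 1 to compound 2 (0.29 log units; within the scatter). This new swap changes several things at once, going from 8 to 11 heavy atoms and from 0 hydrogen-bond acceptors to 1, and no measurement here explains the rise or ties it to any one of these differences.

As far as these compounds go, it remains open whether simpler groups at this place, such as 4-chlorophenyl or 4-methoxyphenyl, would give numbers closer to compound 1 or to compound 3. From the compounds shown here alone, the size of this step with isopropyl on the carbonyl carbon also remains unknown.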